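The compounds below may be only part of what the source reports. "The series", "measured", "known", "first", "only" and "open" are said of these compounds alone.

Compound 1 `Cc1cc(=O)c2c(O)c(CN3CCCC3CO)c(O)c([C@H]3CCN(C)C[C@H]3O)c2o1`: 15%
Compound 2 `Cc1cc(=O)c2c(O)c(CN3CCC(c4ccccc4)CC3)c(O)c([C@H]3CCN(C)C[C@H]3O)c2o1`: 22%
Compound 3 `Cc1oc2c([C@H]3CCN(C)C[C@H]3O)c(O)cc(O)c2c(=O)c1C(O)c1ccc(Cl)cc1`: 41%

In a functional assay on PC-3 cells (Homo sapiens) for inhibition, read by MTT assay, with a stated time of 48 h, tested at 10 uM (on this read-out lower numbers stand for less inhibition of growth and higher numbers for more inhibition of growth at the one concentration tested), compound 3 gives 41%, the highest of the three numbers. Compound 2 and compound 1 both lie lower, and both gaps to compound 3 go beyond the usual scatter. Compound 4 `Cc1oc2c([C@H]3CCN(C)C[C@H]3O)c(O)cc(O)c2c(=O)c1C(O)c1c(Cl)cccc1Cl` has not yet been measured. It carries 2,6-dichlorophenyl in place of 4-chlorophenyl on a saturated chain carbon bound to an aromatic carbon and an oxygen on a saturated carbon. Among the measured compounds shown here, no measured pair shows what such a change does, so no step beyond the scatter is expected in this assay. The expected step is a number 1 percentage points lower from compound 3 to compound 4 (within the scatter). Compound 4 is estimated at 40%, with an expected range from 22% to 60%.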

Compound 4, percent growth inhibition at one concentration: 0%
For compound 4 the middle estimate is 40 percentage points above the measured one; the measured number lies below the stated range.
By their numbers in this assay, from the lowest: compound 4; then compounds 1 and 2 (each within the scatter of the next); then compound 3.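

In this assay, the change from (4-chlorophenyl)(hydroxy)methyl to (2,6-dichlorophenyl)(hydroxy)methyl brings a number 41 percentage points lower from compound 3 to compound 4 (beyond the scatter). Among the compounds shown here, this shows that growth inhibition at this position depends strongly on how the phenyl ring carries its chlorine, which the earlier compounds could not show because no measured pair differed in one place. Nothing at hand explains the loss. The compounds shown leave open whether the added chlorine or the changed chlorine pattern accounts for it, and how plain phenyl or pyridyl would behave on the same carbon.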